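The compounds below may be only part of what the source reports. "The series", "measured", "known", "first", "only" and "open" are said of these compounds alone.

Series notes. Compound 1 `COC(=O)CC(=O)N1N=C(c2ccc(N3CCN(C)CC3)cc2)CC1c1ccc(N(C)C)cc1` gives -0.4% in a functional assay on MDA-MB-231 cells (Homo sapiens) for inhibition, read by sulforhodamine B assay, tested at 10 uM; on this read-out higher numbers stand for more inhibition at the one concentration tested (going by the name of the read-out) and lower numbers for less inhibition. Compound 2 `CN1CCN(c2ccc(C3=NN(C(=O)c4ccc(F)cc4)C(c4ccc(N(C)C)cc4)C3)cc2)CC1` differs from it by 4-fluorophenyl in place of (methoxycarbonyl)methyl on a carbonyl carbon and gives 3.5% in this assay; that step is a number 3.9 percentage points higher from compound 1 to compound 2 (within the scatter). Compound 3 `COC(=O)CC(=O)N1N=C(c2ccc(-n3ccnc3)cc2)CC1c1ccc(N(C)C)cc1` gives 2.3% in this assay; its core differs from the core of compound 1 by 1H-imidazol-1-yl in place of 4-methylpiperazin-1-yl on an aromatic carbon, and the step is a number 2.7 percentage points higher from compound 1 to compound 3 (within the scatter). Compound 4 `CN(C)c1ccc(C2CC(c3ccc(-n4ccnc4)cc3)=NN2C(=O)c2ccc(F)cc2)cc1` is not yet measured. It differs from compound 3 by 4-fluorophenyl in place of (methoxycarbonyl)methyl on a carbonyl carbon, the same change as from compound 1 to compound 2, at a place described in the same words. Because the earlier step was a number 3.9 percentage points higher from compound 1 to compound 2 (within the scatter), a step of similar size is expected here, estimated as a number 3.7 percentage points higher from compound 3 to compound 4 (within the scatter). Compound 4 is therefore expected to give 6% in this assay, with an estimated range from -6% to 18%.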

Compound 4, a percentage reported as inhibition, at one concentration (the size of the read-out at that concentration, not a potency): 9.4%
Compound 4: the middle estimate sits 3.4 percentage points below what was measured, within the range that was stated.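

In this assay the change to 4-fluorophenyl from (methoxycarbonyl)methyl on the carbonyl carbon reads a number 7.1 percentage points higher from compound 3 to compound 4 (within the scatter) and matches its earlier counterpart: the same change on two cores in this assay, a number 3.9 percentage points higher (within the scatter) from compound 1 to compound 2 and a number 7.1 percentage points higher (within the scatter) from compound 3 to compound 4, 3.2 percentage points apart, within the scatter of two such steps.
The change to 1H-imidazol-1-yl from 4-methylpiperazin-1-yl reads a number 5.9 percentage points higher from compound 2 to compound 4 (within the scatter) and likewise matches: the same change on two cores in this assay, a number 2.7 percentage points higher (within the scatter) from compound 1 to compound 3 and a number 5.9 percentage points higher (within the scatter) from compound 2 to compound 4, 3.2 percentage points apart, within the scatter of two such steps.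
Both changes therefore carry from one core to the other without a detectable difference, but with every step within the scatter, this does not show that either change raises inhibition or that the steps truly add up.

Open, as far as these compounds go, is whether a carboxylic acid or a longer alkyl chain on the carbonyl carbon would give a step beyond the scatter. Also open, from the compounds shown here alone, is whether a primary amine on the aromatic carbon would do so.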